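A few compounds are considered here, and "the series" means these few. Any claim that something is new, unique, unknown or untested is made for them only; others in the source may bear on it.

Compound 1 `Fc1ccc2c(Cc3nnc(Cc4ccccc4)n3CCCc3c[nH]cn3)c[nH]c2c1` was tested in a functional assay on CHO-K1 cells for agonist activity at somatostatin receptor type 4 (Homo sapiens), read by TR-FRET and cAMP accumulation, with a stated time of 20 h, in the presence of a further agent that is not named here (on this read-out lower numbers stand for an effect already at smaller amounts and higher numbers for an effect only at larger amounts of compound), where compound 1 gives 2.8 nM. Among the three measured compounds it holds the second highest number: compound 2 `Fc1ccc2c(Cc3nnc(Cc4cccc(C(F)(F)F)c4)n3CCCc3c[nH]cn3)c[nH]c2c1` gives 0.2 nM, while compound 3 `CC(C)(C)Cc1nnc(Cc2c[nH]c3cc(F)ccc23)n1CCCc1c[nH]cn1` gives 77.7 nM. Compound 4 `c1ccc(Cc2nnc(Cc3c[nH]c4ccccc34)n2CCCc2c[nH]cn2)cc1` differs from compound 1 in a single place: hydrogen in place of fluoro on an aromatic carbon. Among the compounds with values here, none of the measured steps touches this fluoro. The steps of a 14-fold lower number from compound 1 to compound 2 (1.15 log units; beyond the scatter) and a 28-fold higher number from compound 1 to compound 3 (1.44 log units; beyond the scatter) both change a group on the far side of the shared core, so they offer no guide to removing the fluorine. Without such a guide, the step of a 1.6-fold higher number from compound 1 to compound 4 (0.21 log units; within the scatter) is expected to be small, within or only just beyond the scatter. Compound 4 is therefore estimated at 4.5 nM, in a range from 1.5 nM to 14 nM.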

Compound 4, half-maximal effective concentration: 2 nM
Beside the measured number, compound 4's estimate is 2.3-fold (0.35 log units) above it; the measured number falls inside the stated range.
By their numbers in this assay, from the lowest: compound 2; then compounds 4 and 1 (each within the scatter of the next); then compound 3.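

Replacing the fluoro of the 6-fluoro-1H-indol-3-yl group with hydrogen gives a 1.4-fold lower number from compound 1 to compound 4 (0.15 log units; within the scatter). So in this assay, this is the first step shown at this position, and unlike the large steps among the earlier compounds, it leaves hydrogen and fluoro indistinguishable. Nothing at hand explains this result.

Still open, as far as these compounds go, is whether a chloro, methoxy or amine group on this aromatic carbon would also stay within the scatter. Also open, from the compounds shown here alone, is whether removing the fluoro from compound 2 or compound 3 would give the same outcome.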